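The source may report more compounds than this note shows. Statements on the series, on what has been measured and on what is new or still open speak of the compounds shown alone.

Compound 1, `CCCCNC(=O)[C@H]1OC(n2cnc3c(N)ncnc32)[C@H](O)[C@@H]1O`, carries a butyl group on its amide-type nitrogen and in an assay on cell membranes for binding affinity to 2-oxoglutarate receptor 1 (Rattus norvegicus), read by radioligand binding (a lower number here means a stronger inhibitor, a higher number a weaker inhibitor), compound 1 gives 17 nM. Compound 2, `Nc1ncnc2c1ncn2C1O[C@H](C(=O)NC2CCCCCCC2)[C@@H](O)[C@H]1O`, shares the same core and differs only in that a cyclooctyl group sits on that nitrogen; in this assay compound 2 gives 23 nM. The step of a 1.4-fold higher number from compound 1 to compound 2 (0.13 log units; within the scatter) shows that exchanging the butyl for the larger ring left the binding essentially unchanged. Among the two numbers known, compound 2 stands at the higher one, but with compound 1 so close that the two cannot be told apart.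

Compound 3, `Nc1ncnc2c1ncn2C1O[C@H](C(=O)NC2CC3CCC2C3)[C@@H](O)[C@H]1O`, keeps everything else and changes the group on the amide-type nitrogen once more: a group of 7 heavy atoms (7 carbon; 2 five-membered non-aromatic rings of carbon only) in place of a group of 8 heavy atoms (8 carbon; one eight-membered non-aromatic ring of carbon only), on an amide-type nitrogen. Within the data shown here, the only comparable step measured, from compound 1 to compound 2, was within the scatter, so a ring-for-ring swap of similar size on this nitrogen is expected to make no difference beyond the scatter in this assay. The step from compound 2 to compound 3 is therefore estimated at a 1.1-fold higher number from compound 2 to compound 3 (0.04 log units; within the scatter). Compound 3 is thus expected to give about 25 nM, with a likely range from 10 nM to 60 nM.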

Compound 3, inhibition constant: 640 nM
Compound 3: the middle estimate sits 26-fold (1.41 log units) below what was measured; the measured number lies above the stated range.
By their numbers in this assay, from the lowest: compounds 1 and 2 (each within the scatter of the next); then compound 3.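

The amide-type nitrogen does not treat all carbon-only groups alike: butyl and cyclooctyl gave numbers within the scatter of each other in this assay, but the two-ring group brought large steps, with a 28-fold higher number from compound 2 to compound 3 (1.44 log units; beyond the scatter) and a 38-fold higher number from compound 1 to compound 3 (1.58 log units; beyond the scatter). Heavy-atom count does not put these three results in order, since the two-ring group has fewer heavy atoms than cyclooctyl and more than butyl, yet compound 3 has the highest number of the three. No measurement at hand explains why this change weakens binding so strongly.

Among these compounds, with only three carbon-only groups, it remains open which feature of the two-ring group goes with the higher number, and whether a single ring such as cyclopentyl or cyclohexyl would give a number close to those of compound 1 and compound 2 or close to that of compound 3. From the compounds shown here alone, it is also open how a longer chain such as octyl, or a butyl chain ending in a hydroxyl group or an amine, would behave on this nitrogen in this assay.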